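A few compounds are considered here, and "the series" means these few. Any claim that something is new, unique, unknown or untested is made for them only; others in the source may bear on it.

Compound 1 `N#CC1(NC(=O)[C@@H]2C[C@@H](S(=O)(=O)c3ccccc3)CN2C(=O)c2ccccc2)CC1` is the starting point: in an assay on isolated protein for inhibition of cathepsin S (Homo sapiens), read by fluorescence, with a stated time of 20 min (a lower number here means a stronger inhibitor, a higher number a weaker inhibitor), compound 1 gives 13 nM. Compound 2 `N#CC1(NC(=O)[C@@H]2C[C@@H](S(=O)(=O)c3ccccc3Cl)CN2C(=O)c2ccccc2)CC1` carries a chloro in place of hydrogen on an aromatic carbon, and in this assay compound 2 gives 0.8 nM. Going by the values given here, of the two numbers measured so far, compound 2 stands with the lower one, the stronger inhibitor of the pair. Compound 3 `CC(=O)N1C[C@H](S(=O)(=O)c2ccccc2Cl)C[C@H]1C(=O)NC1(C#N)CC1` changes a different part of the shared core: methyl in place of phenyl on a carbonyl carbon. Among the compounds with values here, the single measured step, a 16-fold lower number from compound 1 to compound 2 (1.21 log units; beyond the scatter), concerns the chloro on the aromatic ring and not this carbonyl carbon, so it gives no direct guide to what the benzoyl-to-acetyl exchange will do. With the phenyl gone, a moderate rise in the number is expected rather than a fall, a 5.0-fold higher number from compound 2 to compound 3 (0.70 log units; beyond the scatter). Compound 3 is therefore estimated at 4 nM, with a likely range from 0.8 nM to 20 nM.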

Compound 3, half-maximal inhibitory concentration: 1 nM
Beside the measured number, compound 3's estimate is 4.0-fold (0.60 log units) above it; the range from low to high includes it.
By their numbers in this assay, from the lowest: compounds 2 and 3 (each within the scatter of the next); then compound 1.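

On the carbonyl carbon, methyl in place of phenyl gives a 1.3-fold higher number from compound 2 to compound 3 (0.10 log units; within the scatter) in this assay, so compound 2 and compound 3 cannot be told apart in this measurement. Until now this position had carried only phenyl, and the result shows that a single methyl carbon can stand there instead of the six-carbon aromatic ring with no change beyond the scatter, at least when the chloro is present on the other aromatic ring. No measurement at hand explains why the benzoyl-to-acetyl exchange leaves the number where it is.

Open questions remain at this carbonyl carbon: whether an amine or a longer chain such as butyl would stay in the same range. On these data alone, it is also open whether the same exchange would behave alike on compound 1, which has no chloro.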